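A few compounds are considered here, and "the series" means these few. Any claim that something is new, unique, unknown or untested is made for them only; others in the source may bear on it.

In a functional assay on MGC-803 cells (Homo sapiens) for cytotoxicity, read by MTT assay, with a stated time of 72 h (a higher number here means a weaker inhibitor, a lower number a stronger inhibitor), compound 1 `CC(C)=C1C(=O)N(c2ccc(Cl)cc2)N(c2ccc(Cl)cc2)C1=O` gives 39000 nM and compound 2 `O=C1C(=Cc2ccc(O)cc2)C(=O)N(c2ccc(Cl)cc2)N1c1ccc(Cl)cc1` gives 19500 nM as its reading, so these two values lie within the usual scatter of each other. Compound 3 `CC(=C1C(=O)N(c2ccc(Cl)cc2)N(c2ccc(Cl)cc2)C1=O)c1ccc(O)cc1` keeps the shared core of compound 2 and carries a single change, methyl in place of hydrogen on a double-bonded chain carbon bound to an aromatic carbon and a double-bonded ring carbon in all: methyl in place of hydrogen on a double-bonded chain carbon bound to an aromatic carbon and a double-bonded ring carbon. Among the compounds with values here, no measured pair shows what this swap does, so no step beyond the scatter is expected in this assay here. The estimated step of a 1.0-fold higher number from compound 2 to compound 3 (0.01 log units; within the scatter) is expected to stay within that scatter. Compound 3 is estimated at 20000 nM with an expected range from 8000 nM to 50000 nM as the likely span.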

Compound 3, half-maximal inhibitory concentration: 42800 nM
The estimate for compound 3 lay 2.1-fold (0.33 log units) below the measured number; measured number inside the range.
By their numbers in this assay, from the lowest: compounds 2, 1 and 3 (each within the scatter of the next, the first and the last beyond it).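

In this assay, methyl in place of hydrogen on a double-bonded chain carbon bound to an aromatic carbon and a double-bonded ring carbon gives a 2.2-fold higher number from compound 2 to compound 3 (0.34 log units; beyond the scatter), so this carbon responds, modestly, to one added methyl. The swap of 4-hydroxyphenyl in place of methyl gives a 1.1-fold higher number from compound 1 to compound 3 (0.04 log units; within the scatter), so these two compounds, each with a methyl on that carbon, cannot be told apart here. Nothing available explains either step.

As far as these compounds go, whether an ethyl chain or an amine on that same carbon would push the number further or reverse it stays open.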